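Series notes: the step from compound 3 to compound 4

This account rests on a few compounds, and the source may have more. Where it says the series, first, only, none or still open, it means among the compounds named here.

Measured so far:
compound 1 `CC(C)n1cnc2c(Nc3ccccc3)nc(NCOCc3ccc(C(=O)Nc4ccccc4N)cc3)nc21`: 50.2%
compound 2 `CCC(C)n1cnc2c(NCc3ccc(C(=O)Nc4ccccc4N)cc3)nc(Cl)nc21`: 65%
compound 3 `Cc1ccc(Nc2nc(Cl)nc3c2ncn3Cc2ccc(C(=O)Nc3ccccc3N)cc2)cc1`: 82%

In a functional assay on HepG2 cells (Homo sapiens) for antiproliferative activity, read by CCK-8 assay, with a stated time of 72 h, tested at 8 uM (on this read-out higher numbers stand for a stronger effect at the one concentration tested and lower numbers for a weaker effect), compound 3 stands highest of the three numbers. Compound 2 is the nearest, its number lower beyond the scatter; compound 1 is furthest, lower again beyond the scatter. Compound 4 `Nc1ccccc1NC(=O)c1ccc(Cn2cnc3c(Nc4cccc(Cl)c4)nc(Cl)nc32)cc1` differs from compound 3 in one place: 3-chlorophenyl in place of 4-methylphenyl on a nitrogen on an aromatic ring. For the measured compounds named here, no pair of measured compounds shows this kind of change on its own, so the series does not fix its direction. The expected step is a number 4 percentage points lower from compound 3 to compound 4 (within the scatter), small and likely within the scatter, since the remainder of compound 3 is kept unchanged. Compound 4 is estimated at 78%, with a range from 60% to 92%.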

Compound 4, a percentage reported as inhibition, at one concentration (the size of the read-out at that concentration, not a potency): 66.7%
For compound 4 the middle estimate is 11.3 percentage points above the measured one; low and high end bracket the measured number.
By their numbers in this assay, from the lowest: compound 1; then compounds 2 and 4 (each within the scatter of the next); then compound 3.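

In this assay the replacement of 4-methylphenyl by 3-chlorophenyl on a nitrogen on an aromatic ring gives a number 15.3 percentage points lower from compound 3 to compound 4 (beyond the scatter) and so shows that the read-out responds to this aryl group with the rest of compound 3 kept. For the compounds shown here, it is the first change in one place, which makes this position the only one with a readable step so far. No measurement at hand accounts for the step.

The compounds shown do not separate the exchange of methyl for chlorine from the shift in where the group sits on the phenyl ring. From the compounds shown here alone, how a methoxy group or an amine on that ring would read also remains open.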